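The source may hold more compounds than are shown below. What is called first, only, known or untested is meant among the compounds shown, and "the series" means these compounds.

Compound 1, `CCNC(=O)[C@H]1O[C@@H](n2cnc3c(NNC(=O)c4cccnc4)ncnc32)[C@H](O)[C@@H]1O`, was tested in a functional assay on CHO cells for activation of adenosine receptor A2b (Homo sapiens), read by cAMP accumulation; a higher number here means that more compound is needed for the effect, a lower number that less compound is needed; compound 1 gives > 5000 nM, which is a limit of the assay and not a number. Compound 2, `CCNC(=O)[C@H]1O[C@@H](n2cnc3c(NNC(=O)c4ccccc4)nc(Cl)nc32)[C@H](O)[C@@H]1O`, gives > 5000 nM in this assay, again a limit rather than a measured number. Compound 2 thus stands at the ceiling of what the assay reports, and compound 1 sits at the same place: the limit of > 5000 nM in this assay, at which 2 of the 2 values shown sit. Compound 3, `CCNC(=O)[C@H]1O[C@@H](n2cnc3c(NNC(=O)c4cc(-c5ccccc5)on4)nc(Cl)nc32)[C@H](O)[C@@H]1O`, has not yet been measured. It differs from compound 2 in one place: 5-phenyl-1,2-oxazol-3-yl in place of phenyl on a carbonyl carbon. Among the measured compounds shown here, no measured pair shows what such a change does in this setting, so no direction can be read from the data. The step that the limit leaves unreadable from compound 2 to compound 3 is expected to be none beyond the scatter. Compound 3 is expected to give about 8000 nM in this assay, with a range from 2000 nM to 30000 nM, most likely reported once more only as a limit.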

Compound 3, half-maximal effective concentration: > 5000 nM
Compound 3: only a limit was reported; the forecaster's own chance of this, stated with the estimate: 75%; the middle value does not contradict the limit.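

Compound 3 also gives > 5000 nM in this assay, again a limit and not a number. No step from compound 2 to compound 3 can therefore be read: the limit of > 5000 nM in this assay, at which 3 of the 3 values shown sit.

The compounds shown leave open what 5-phenyl-1,2-oxazol-3-yl in place of phenyl does to the value, and which change would bring a measurable number.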